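The source may hold more compounds than are shown below. What is called first, only, known or untested is meant among the compounds shown, and "the series" means these compounds.

Measured so far in a functional assay on OVCAR-4 cells (Homo sapiens) for inhibition; a higher number here means a weaker inhibitor of growth, a lower number a stronger inhibitor of growth:
Compound 1 `Cc1cc(-c2nc3cc(F)c(F)cc3s2)ccc1N` gives 60300 nM.
Compound 2 `Nc1ccc(-c2nc3cc(F)ccc3s2)cc1I` gives < 10 nM, which is a limit of the assay rather than a number.
Compound 3 `Cc1cc(-c2nc3ccc(F)cc3s2)ccc1N` gives 10 nM.

Compound 2 thus stands at the strong end of the values shown, sitting at the limit of < 10 nM in this assay, at which 1 of the 3 values shown sits. Compound 4 `Nc1ccc(-c2nc3cc(F)ccc3s2)cc1Cl` differs from compound 2 by chloro in place of iodo on an aromatic carbon. Among the measured compounds shown here, the only measured step, a 6000-fold lower number from compound 1 to compound 3 (3.78 log units; beyond the scatter), concerns a different group at a different place on the shared core, so no measured step bears directly on this change. With nothing comparable to draw on, only a modest step in this assay, if any beyond the scatter, is expected: an at least 1.5-fold higher number from compound 2 to compound 4 (0.17 log units; that floor lies within the scatter). The estimate for compound 4 is 15 nM, with a range from 5 nM to 60 nM.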

Compound 4, concentration for 50% growth inhibition: 320 nM
Beside the measured number, compound 4's estimate is 21-fold (1.33 log units) below it; the measured number lies above the stated range.
By their numbers in this assay, from the lowest: compound 3; then compound 4; then compound 1.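

At the place ortho to an amino group, exchanging one single-atom group for another can matter greatly: in this assay, chloro in place of iodo gives an at least 32-fold higher number from compound 2 to compound 4 (1.50 log units; beyond the scatter). The value of compound 2 is a limit and not a number: the limit of < 10 nM in this assay, at which 1 of the 4 values shown sits. Among the compounds shown here, the earlier large step concerned a different place on the shared core, so this is the first sign that this position also matters.

On these data alone, how bromo or a methoxy group at this position would compare with iodo and chloro stays open.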